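A few compounds are considered here, and "the series" means these few. Any claim that something is new, unique, unknown or untested is made for them only; others in the source may bear on it.

In a functional assay on HCT-116 cells (Homo sapiens) for inhibition (on this read-out higher numbers stand for weaker inhibition of growth and lower numbers for stronger inhibition of growth), compound 3 (`Oc1cc(O)c(-c2[nH]ncc2-c2ccc(-c3ccc(F)cc3)cc2)cc1Cl`) gives 11000 nM. Compound 2 (`Cc1n[nH]c(-c2cc(Cl)c(O)cc2O)c1-c1ccccc1`) gives 6400 nM, which lies within the scatter of compound 3. Compound 1 (`Cc1n[nH]c(-c2cc(Cl)c(O)cc2O)c1-c1ccc(OCCCC#N)cc1`) gives 3600 nM. The gap between compound 3 and compound 1 lies beyond the scatter. Compound 4 (`N#CCCCOc1ccc(-c2cn[nH]c2-c2cc(Cl)c(O)cc2O)cc1`) carries 3-cyanopropoxy in place of 4-fluorophenyl on an aromatic carbon. Going by the values given here, no measured step makes this exchange directly. The nearest evidence is a 1.8-fold higher number from compound 1 to compound 2 (0.25 log units; within the scatter), which swaps 3-cyanopropoxy for hydrogen on a core not identical to that of compound 4. Compound 1 does carry 3-cyanopropoxy, and its 3600 nM suggests a modest move towards a lower number in this assay. The expected change is a 2.4-fold lower number from compound 3 to compound 4 (0.39 log units; beyond the scatter). Compound 4 is estimated at 4500 nM, with an expected range of 1800 nM to 11000 nM.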

Compound 4, concentration for 50% growth inhibition: 6800 nM
Estimate against measurement, compound 4: 1.5-fold (0.18 log units) below; the range from low to high includes it.
By their numbers in this assay, from the lowest: compounds 1, 2, 4 and 3 (each within the scatter of the next, the first and the last beyond it).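

In this assay, 3-cyanopropoxy in place of 4-fluorophenyl gives a 1.6-fold lower number from compound 3 to compound 4 (0.21 log units; within the scatter), so at this place, para to a large group, a chain with no ring and a group carrying an aromatic ring cannot be told apart. With 3-cyanopropoxy held constant, hydrogen in place of methyl on an aromatic carbon gives a 1.9-fold higher number from compound 1 to compound 4 (0.28 log units; within the scatter), which also stays within the scatter. Nothing available gives a reason for either result.

From the compounds shown here alone, whether an amine, a carboxylic acid or a longer chain at this place would produce a step beyond the scatter remains open. So does the effect of methyl alongside 4-fluorophenyl.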